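Urea to Amide in a Pyrazole Series

A few compounds are considered here, and "the series" means these few. Any claim that something is new, unique, unknown or untested is made for them only; others in the source may bear on it.

The shared core of compound 2 `COc1cc(Cl)cc(-c2nn(-c3cccc(NC(=O)Nc4ccc(Cl)c(C(F)(F)F)c4)c3)cc2-c2ccncc2)c1` carries a urea linking two aromatic rings. In a functional assay on MDA-MB-435 cells (Homo sapiens) for inhibition, read by sulforhodamine B assay, with a stated time of 48 h, tested at 1 uM (a lower number here means a stronger effect, a higher number a weaker effect of the compound at the concentration tested), compound 2 gives 81%, the second highest of the three numbers measured: its nearest neighbour is compound 3 `COc1cc(Cl)cc(-c2nn(-c3cccc(NC(=O)Nc4ccc(Cl)c(Cl)c4)c3)cc2-c2ccncc2)c1`, which gives 85%, and the step of a number 4 percentage points higher from compound 2 to compound 3 (within the scatter) is a chloro in place of trifluoromethyl on an aromatic carbon. The furthest is compound 1 `O=C(Nc1cccc(-n2cc(-c3ccncc3)c(-c3cc(O)cc(Cl)c3)n2)c1)Nc1ccc(Cl)c(C(F)(F)F)c1`, which gives 57%, with a number 24 percentage points higher from compound 1 to compound 2 (beyond the scatter) for a methyl in place of hydrogen on an oxygen on an aromatic ring.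

Compound 4 `COc1cc(Cl)cc(-c2nn(-c3cccc(NC(=O)c4cccc(C(F)(F)F)c4)c3)cc2-c2ccncc2)c1` differs from compound 2 by 3-(trifluoromethyl)phenyl in place of (4-chloro-3-(trifluoromethyl)phenyl)amino on a carbonyl carbon, that is, on a carbonyl carbon whose other neighbour is an amide-type nitrogen. For the measured compounds named here, no measured step touches this part of the molecule: a number 4 percentage points higher from compound 2 to compound 3 (within the scatter) concerns only a substituent on the ring that leaves, and a number 24 percentage points higher from compound 1 to compound 2 (beyond the scatter) concerns the far ring. Going by the values given here, with no precedent, the expected step of a number 4 percentage points higher from compound 2 to compound 4 (within the scatter) is small and uncertain. Compound 4 is therefore estimated at 85%, within 65% to 100%.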

Compound 4, a percentage reported as activity, at one concentration (the size of the read-out at that concentration, not a potency): 93%
Compound 4: the middle estimate sits 8 percentage points below what was measured, within the range that was stated.
By their numbers in this assay, from the lowest: compound 1; then compounds 2, 3 and 4 (each within the scatter of the next, the first and the last beyond it).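

In this assay, for the compounds shown here, exchanging the (4-chloro-3-(trifluoromethyl)phenyl)amino group on the carbonyl carbon for 3-(trifluoromethyl)phenyl gives a number 12 percentage points higher from compound 2 to compound 4 (beyond the scatter), the first step at this position to go beyond the scatter, and it weakens the effect at the concentration tested. The corresponding exchange from the (3,4-dichlorophenyl)amino group gives a number 8 percentage points higher from compound 3 to compound 4 (within the scatter), so turning the urea into an amide does not clearly weaken the effect against both ureas. The compounds offer no measured explanation for the difference between these two steps.

Going by these compounds, each step changes the amino nitrogen and the ring substituents at once, so their separate contributions remain open. On these data alone, whether a methylene group or an oxygen atom in place of that nitrogen would preserve the effect of the ureas also remains open.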